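Swapping a chloro for methyl on the terminal urea ring

A few compounds are considered here, and "the series" means these few. Any claim that something is new, unique, unknown or untested is made for them only; others in the source may bear on it.

Compound 2 `CN(C)CCCNc1nc(-c2ccc(NC(=O)Nc3ccc(Cl)cc3)cc2)nc2c(Cl)c(Cl)sc12` is measured in a functional assay on NCI-H460 cells (Homo sapiens) for cytotoxicity, read by MTT assay, with a stated time of 72 h (on this read-out lower numbers stand for stronger inhibition and higher numbers for weaker inhibition), at 230 nM. Compound 1 `CN(C)CCCNc1nc(-c2ccc(NC(=O)Nc3ccccc3Cl)cc2)nc2ccsc12` gives 430 nM in this assay, a number within the usual scatter of that of compound 2. Compound 3 `CN(C)CCCNc1nc(-c2ccc(NC(=O)Nc3ccc(Cl)cc3Cl)cc2)nc2ccsc12` gives 1020 nM, and this number lies beyond the scatter from that of compound 2. Among the measured compounds shown here, the one single-point step among the measured compounds, a 2.4-fold higher number from compound 1 to compound 3 (0.38 log units; beyond the scatter), concerns a chloro entering in place of hydrogen on the terminal urea ring rather than a chloro leaving.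

Compound 4 `Cc1ccc(NC(=O)Nc2ccc(-c3nc(NCCCN(C)C)c4sc(Cl)c(Cl)c4n3)cc2)cc1` differs from compound 2 in one place: methyl in place of chloro on an aromatic carbon. For the measured compounds named here, no measured pair shows methyl in place of chloro, so the bearing of the known step is indirect. Going by the values given here, the only measured change on that ring, the step from compound 1 to compound 3, was modest, and a one-atom exchange of chloro for methyl is expected to move this assay by no more than a similar amount, with no clear direction.

Compound 4 is therefore expected to give about 320 nM in this assay, between 120 nM and 850 nM, which is an expected step of a 1.4-fold higher number from compound 2 to compound 4 (0.14 log units; within the scatter) from compound 2.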

Compound 4, half-maximal inhibitory concentration: 1110 nM
Compound 4: middle estimate off by 3.5-fold (0.54 log units), on the low side; measured number outside the range, above it.
By their numbers in this assay, from the lowest: compounds 2 and 1 (each within the scatter of the next); then compounds 3 and 4 (each within the scatter of the next).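

In this assay, the change from 4-chlorophenyl to 4-methylphenyl gives a 4.8-fold higher number from compound 2 to compound 4 (0.68 log units; beyond the scatter) and so shows that this position on the terminal urea ring is sensitive to the exchange of one group for the other. The earlier step on this ring, a 2.4-fold higher number from compound 1 to compound 3 (0.38 log units; beyond the scatter) and with chloro entering in place of hydrogen, showed only the addition of a group, whereas here one heavy atom leaves, one enters, neither side carries a hydrogen-bond donor or acceptor, and the number still moves beyond the scatter. Nothing in the information at hand accounts for this step.

The compounds shown leave open whether the higher number follows from the loss of chloro or the arrival of methyl, and a fluoro, bromo, methoxy or trifluoromethyl group on the same carbon would help to separate the two. They also leave open whether the same exchange would produce a step of similar size on the core of compound 1, which differs from that of compound 2.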